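The source may hold more compounds than are shown below. What is called first, only, known or untested is meant among the compounds shown, and "the series" means these compounds.

Compound 1 `N#Cc1cc(=O)[nH]c(=O)n1[C@@H]1O[C@H](CO)[C@@H](O)[C@H]1O`: > 50000 nM
Compound 2 `O=c1cc(I)n([C@@H]2O[C@H](CO)[C@@H](O)[C@H]2O)c(=O)[nH]1`: > 50000 nM
Compound 3 `Nc1cc(=O)[nH]c(=O)n1[C@@H]1O[C@H](CO)[C@@H](O)[C@H]1O`: > 50000 nM

All three compounds were tested in a functional assay on OCI-AML2 cells (Homo sapiens) for antiproliferative activity, read by WST assay, with a stated time of 3 days; on this read-out lower numbers stand for stronger inhibition and higher numbers for weaker inhibition. Each entry is a limit of the assay and not a number, and the whole picture so far is the limit of > 50000 nM in this assay, at which 3 of the 3 values shown sit. Compound 3 has no number of its own, since its result of > 50000 nM is a limit.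

Compound 4 `CN(C)c1cc(=O)[nH]c(=O)n1[C@@H]1O[C@H](CO)[C@@H](O)[C@H]1O` differs from compound 3 in one place, with dimethylamino in place of amino on an aromatic carbon.

The measured steps that bear on this change are also swaps of one group for another on an aromatic carbon. They are a step that the two limits leave unreadable from compound 1 to compound 2, a step that the two limits leave unreadable from compound 1 to compound 3 and a step that the two limits leave unreadable from compound 2 to compound 3. None of them has a readable size, so none offers a size or direction to carry over. Cyano, iodo and amino in this place have all left the compounds at the limit in this assay, so no change beyond the usual scatter is expected here, and a reading at the same limit is the likeliest result.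

The expected change is a number no higher from compound 3 to compound 4 (the limit leaves the size open), which is an estimate only.

For compound 4 the estimated value is 50000 nM, with an expected range from 20000 nM to 100000 nM.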

Compound 4, half-maximal inhibitory concentration: > 50000 nM
Compound 4: no number, only a limit; the forecaster's own chance of this, stated with the estimate: 80%; the middle value lies on the limit itself.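

In this assay compound 4 gives > 50000 nM as a limit and not a number. No new step can be read from compound 4 to compound 1, compound 2 or compound 3, since all four compounds end at the same limit: the limit of > 50000 nM in this assay, at which 4 of the 4 values shown sit.

The compounds shown leave open whether any group in this place on the shared core can give a measurable number in this assay.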